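Shortening the phosphate chain of a uridine-type nucleotide

A few compounds are considered here, and "the series" means these few. Any claim that something is new, unique, unknown or untested is made for them only; others in the source may bear on it.

Compound 1 `O=c1[nH]c(=O)n([C@@H]2O[C@H](COP(=O)(O)OP(=O)(O)OP(=O)(O)O)[C@@H](O)[C@H]2O)cc1Br` — 3460 nM
Compound 2 `Cc1cc(=O)n([C@@H]2O[C@H](COP(=O)(O)OP(=O)(O)OP(=O)(O)O)[C@@H](O)[C@H]2O)c(=O)[nH]1` — > 100000 nM

Compound 1 was tested in an in vitro functional assay on 1321-N1 cells for agonist activity at P2Y purinoceptor 4 (Homo sapiens) (on this read-out higher numbers stand for an effect only at larger amounts of compound and lower numbers for an effect already at smaller amounts), and gives 3460 nM. Compound 2 gives only a limit in this assay, > 100000 nM, so no number is known for it; it stands at the limit of > 100000 nM in this assay, at which 1 of the 2 values shown sits. For the measured compounds named here, the single measured step, an at least 28-fold higher number from compound 1 to compound 2 (1.46 log units; beyond the scatter), concerns the base and says nothing about the phosphate chain.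

Compound 3 `Cc1cc(=O)n([C@@H]2O[C@H](COP(=O)(O)O)[C@@H](O)[C@H]2O)c(=O)[nH]1` differs from compound 2 by a hydrogen atom in place of a group of 8 heavy atoms (6 oxygen, 2 phosphorus; no ring), on an oxygen. Going by the values given here, no measured pair covers this change, so the expectation for compound 3 rests only on where compound 2 already stands. Since compound 2 sits at the limit, compound 3 is expected to sit there too, and the step that the limit leaves unreadable from compound 2 to compound 3 is therefore expected to be unresolvable rather than a measured change. Compound 3 is estimated at 300000 nM, with a range from 100000 nM to 1000000 nM, and most likely the assay again reports only a limit.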

Compound 3, half-maximal effective concentration: > 100000 nM
Compound 3: only a limit was reported (the forecaster's own chance of this, stated with the estimate: 95%); the middle value lies beyond the limit too.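

In this assay, compound 3 gives > 100000 nM, which is again only a limit, and compound 2 is a limit too, so no step can be read between compound 2 and compound 3. The compounds shown leave open what a hydrogen atom in place of the group of 8 heavy atoms does to the response: neither compound of this pair gives a number.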